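The compounds below may be only part of what the source reports. "The series", "measured", "known", "first", "only" and "open" are said of these compounds alone.

Working notes on a set of four nitroimidazole-bearing compounds tested for cytotoxicity. Compound 1 `Cc1ncc([N+](=O)[O-])n1CCSc1nnc(-c2ccccc2N)o1` and compound 2 `Cc1ncc([N+](=O)[O-])n1CCSc1nnc(-c2ccc(N)cc2)o1` have the same atoms joined differently; the counted difference is 4-aminophenyl in place of 2-aminophenyl on an aromatic carbon. Compound 3 `CCOc1ccccc1-c1nnc(SCCn2c([N+](=O)[O-])cnc2C)o1` differs from compound 1 by ethoxy in place of amino on an aromatic carbon. Compound 4 `CCOc1ccc(-c2nnc(SCCn3c([N+](=O)[O-])cnc3C)o2)cc1` has not yet been measured.

In a functional assay on MCF7 cells (Homo sapiens) for cytotoxicity, read by MTT assay, with a stated time of 48 h (on this read-out lower numbers stand for stronger inhibition and higher numbers for weaker inhibition), compound 1 gives 20100 nM, compound 2 gives 19800 nM and compound 3 gives 25900 nM. All three values sit close together. The step of a 1.0-fold lower number from compound 1 to compound 2 (0.01 log units; within the scatter) shows that moving the amino group from the 2-position to the 4-position of the phenyl ring leaves the read-out essentially unchanged. The step of a 1.3-fold higher number from compound 1 to compound 3 (0.11 log units; within the scatter) shows that replacing amino with ethoxy also stays within the scatter.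

Compound 4 differs from compound 2 by ethoxy in place of amino on an aromatic carbon. Among the measured compounds shown here, this is the same kind of change as the one from compound 1 to compound 3, not the same change: in the earlier case the place is ortho to a large group, here it is para to a large group. Since the earlier step of a 1.3-fold higher number from compound 1 to compound 3 (0.11 log units; within the scatter) was within the scatter, and the 2-position versus 4-position placement also made no difference in a 1.0-fold lower number from compound 1 to compound 2 (0.01 log units; within the scatter), a similarly small step is expected here. The step from compound 2 to compound 4 is estimated at a 1.3-fold higher number from compound 2 to compound 4 (0.10 log units; within the scatter). For compound 4 in this assay the expected value is 25000 nM, with a likely range from 12000 nM to 50000 nM.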

Compound 4, half-maximal inhibitory concentration: 16600 nM
Beside the measured number, compound 4's estimate is 1.5-fold (0.18 log units) above it; the measured number falls inside the stated range.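

In this assay, ethoxy in place of amino gives a 1.2-fold lower number from compound 2 to compound 4 (0.08 log units; within the scatter), and set beside the same change on the core of compound 1, the two steps cannot be told apart: the same change on two cores in this assay, a 1.3-fold higher number (0.11 log units; within the scatter) from compound 1 to compound 3 and a 1.2-fold lower number (0.08 log units; within the scatter) from compound 2 to compound 4, 1.5-fold (0.19 log units) apart, within the scatter of two such steps

On these two cores, then, the exchange of amino for ethoxy on the phenyl ring carries over only in the sense that neither step can be told from repeat-measurement noise, so a small step on one core went with a small step on the other. This does not show a shared direction or a shared size for the change, since no direction can be read from either step, and it says nothing about cores beyond these two, which are close relatives carrying 2-aminophenyl and 4-aminophenyl and whose four compounds all lie within a narrow band of values.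

Going by these compounds, what a carboxylic acid, a nitrile or a longer alkoxy chain such as butoxy would do in place of amino on either core remains open, and so does whether any group on this phenyl ring can move the read-out beyond the scatter. Whether the same flat picture holds on other cell lines, or at exposure times other than the one stated, is also left open.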